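The compounds below may be only part of what the source reports. "The series", "measured", "known", "first", "only" and "open" are said of these compounds alone.

Measured compounds in a functional assay on CAPAN-1 cells (Homo sapiens) for antiproliferative activity, with a stated time of 72 h; on this read-out higher numbers stand for weaker inhibition and lower numbers for stronger inhibition:
- compound 1 `CCCC#Cc1cc([C@@H]2O[C@H](CO)[C@@H](O)[C@H]2O)n2ncnc(N)c12`: 20 nM
- compound 2 `Nc1ncnn2c([C@@H]3O[C@H](CO)[C@@H](O)[C@H]3O)cc(-c3ccc(F)cc3F)c12`: 50900 nM

Within the data shown here, compound 2 has the highest of the two numbers in this assay; its only neighbour is compound 1, and the step of a 2500-fold higher number from compound 1 to compound 2 (3.41 log units; beyond the scatter) separates them. Compound 3 `Nc1ncnn2c([C@@H]3O[C@H](CO)[C@@H](O)[C@H]3O)cc(-c3ccccc3Cl)c12` differs from compound 2 in one place: 2-chlorophenyl in place of 2,4-difluorophenyl on an aromatic carbon. Among the measured compounds shown here, no measured step covers such an exchange of one aryl group for another; the single step of a 2500-fold higher number from compound 1 to compound 2 (3.41 log units; beyond the scatter) concerns a chain against an aryl group and only shows that an aryl group at this position sits at the weak end. The step of a 1.7-fold lower number from compound 2 to compound 3 (0.23 log units; within the scatter) is therefore expected to be small, not clearly beyond the scatter. Compound 3 is estimated at 30000 nM, range 5000 nM to 150000 nM.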

Compound 3, half-maximal inhibitory concentration: 54900 nM
Estimate against measurement, compound 3: 1.8-fold (0.26 log units) below; the measured number falls inside the stated range.
By their numbers in this assay, from the lowest: compound 1; then compounds 2 and 3 (each within the scatter of the next).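

In this assay, 2-chlorophenyl in place of 2,4-difluorophenyl gives a 1.1-fold higher number from compound 2 to compound 3 (0.03 log units; within the scatter), so these two aryl groups on this aromatic carbon cannot be told apart. The large gap to the pent-1-yn-1-yl chain recurs with a second aryl group, at a 2700-fold higher number from compound 1 to compound 3 (3.44 log units; beyond the scatter), so the weak end is not tied to the 2,4-difluorophenyl group alone. No supporting data are available to explain these results.

As far as these compounds go, whether a plain phenyl, an amine or a longer chain on this carbon would lie nearer compound 1 or nearer compound 2 stays open.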